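A few compounds are considered here, and "the series" means these few. Any claim that something is new, unique, unknown or untested is made for them only; others in the source may bear on it.

Of the compounds shown here, three built on one shared core have been measured in a functional assay on PC-3 cells (Homo sapiens) for cytotoxicity, read by MTT assay, with a stated time of 72 h; a higher number here means a weaker inhibitor, a lower number a stronger inhibitor. Compound 1 `FC(F)(F)c1ccc(CSc2nc(Nc3ccccc3)c3ccccc3n2)cc1` gives 20000 nM. Compound 2 `FC(F)(F)c1ccc(CSc2nc(Nc3ccccc3C(F)(F)F)c3ccccc3n2)cc1` gives 34800 nM, the highest number of the three; its nearest neighbour is compound 1, since a 1.7-fold higher number from compound 1 to compound 2 (0.24 log units; within the scatter), and the widest gap is to compound 3, since a 4.9-fold lower number from compound 2 to compound 3 (0.69 log units; beyond the scatter). Compound 3 `Fc1ccc(Nc2nc(SCc3ccc(C(F)(F)F)cc3)nc3ccccc23)cc1` gives 7070 nM, and from compound 1 the step is a 2.8-fold lower number from compound 1 to compound 3 (0.45 log units; beyond the scatter).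

Compound 4 `FC(F)(F)c1ccc(CSc2nc(Nc3ccc(Cl)cc3)c3ccccc3n2)cc1` has not yet been measured. It differs from compound 2 in one place: 4-chlorophenyl in place of 2-(trifluoromethyl)phenyl on a nitrogen on an aromatic ring. Within the data shown here, the measured step that bears most directly on this change is the one from compound 2 to compound 3, where a 4.9-fold lower number from compound 2 to compound 3 (0.69 log units; beyond the scatter) accompanied the replacement of 2-(trifluoromethyl)phenyl by 4-fluorophenyl. Among the measured compounds shown here, compound 4 makes the same exchange, but with 4-chlorophenyl entering instead, and no measured pair shows how 4-chlorophenyl compares with 4-fluorophenyl at this place. A step of similar size and direction to the measured step from compound 2 to compound 3 is therefore expected here. The expected step is a 4.4-fold lower number from compound 2 to compound 4 (0.64 log units; beyond the scatter). Compound 4 is estimated at 8000 nM, with a range from 3000 nM to 25000 nM.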

Compound 4, half-maximal inhibitory concentration: 7110 nM
For compound 4 the middle estimate is 1.1-fold (0.05 log units) above the measured one; the measured number falls inside the stated range.
By their numbers in this assay, from the lowest: compounds 3 and 4 (each within the scatter of the next); then compounds 1 and 2 (each within the scatter of the next).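

In this assay, the step of a 4.9-fold lower number from compound 2 to compound 4 (0.69 log units; beyond the scatter) shows that the earlier gain on leaving 2-(trifluoromethyl)phenyl was not tied to 4-fluorophenyl alone, since a second group entering at the same nitrogen gives a step of the same size. Chloro and fluoro on this ring cannot be told apart, with a 1.0-fold higher number from compound 3 to compound 4 (0.00 log units; within the scatter) and that step lying within the scatter, and chloro in place of hydrogen gives a 2.8-fold lower number from compound 1 to compound 4 (0.45 log units; beyond the scatter) and so goes the same way as a 2.8-fold lower number from compound 1 to compound 3 (0.45 log units; beyond the scatter) while compound 2 goes against this pattern, its step of a 1.7-fold higher number from compound 1 to compound 2 (0.24 log units; within the scatter) lying within the scatter. No evidence in hand explains why these numbers fall as they do.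

Still open, from the compounds shown here alone, is whether the same place would accept a phenyl ring carrying a methoxy group, a nitrile or a carboxylic acid in place of chloro, or whether only chloro and fluoro give this result. Also open, going by these compounds, is whether these steps would hold if the rest of the molecule changed, since all four compounds share the same core and the same 4-(trifluoromethyl)benzyl group on sulfur.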